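Methyl in place of fluoro on compound 2

This account rests on a few compounds, and the source may have more. Where it says the series, first, only, none or still open, it means among the compounds named here.

In a functional assay on MDA-MB-231 cells (Homo sapiens) for cytotoxicity, read by MTT assay, with a stated time of 24 h (on this read-out lower numbers stand for stronger inhibition and higher numbers for weaker inhibition), compound 1 `NCC(=O)NCc1nnc(-c2ccccc2)o1` gives 283 nM, compound 2 `NCC(=O)NCc1nnc(-c2ccc(F)cc2)o1` gives 254 nM and compound 3 `C[C@@H](N)C(=O)NCc1nnc(-c2ccc(F)cc2)o1` gives 247 nM. Compound 2 lies within the scatter of both other compounds, so these three numbers show no order.

Compound 4 `Cc1ccc(-c2nnc(CNC(=O)CN)o2)cc1` is the next to be read against compound 2. The difference is methyl in place of fluoro on an aromatic carbon, para to a large group.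

Within the data shown here, two measured steps bear on this change. Fluoro in place of hydrogen on an aromatic carbon gave a 1.1-fold lower number from compound 1 to compound 2 (0.05 log units; within the scatter). Methyl in place of hydrogen on a saturated chain carbon gave a 1.0-fold lower number from compound 2 to compound 3 (0.01 log units; within the scatter), at a different place in the structure. Among the measured compounds shown here, no measured step exchanges fluoro for methyl directly, and no measured compound carries methyl on the aromatic ring.

No step beyond the scatter is expected, and the estimated step is a 1.0-fold higher number from compound 2 to compound 4 (0.01 log units; within the scatter) in this assay. For compound 4 the expected value is 260 nM, with an estimated range of 140 nM to 480 nM.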

Compound 4, half-maximal inhibitory concentration: 260 nM
The estimate for compound 4 equals the measured number at the digits printed; low and high end bracket the measured number.
By their numbers in this assay, from the lowest: compounds 3, 2, 4 and 1 (each within the scatter of the next).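

In this assay, on an aromatic carbon para to a large group, methyl in place of fluoro gives a 1.0-fold higher number from compound 2 to compound 4 (0.01 log units; within the scatter), and methyl in place of hydrogen gives a 1.1-fold lower number from compound 1 to compound 4 (0.04 log units; within the scatter). The earlier compounds shown here compared only fluoro with hydrogen at this position; with methyl added, all three substituents lie within the scatter of one another and show no order. No separate measurement is available to account for these numbers.

Still open, going by these compounds, is whether a trifluoromethyl, methoxy or nitrile group at this position, or a carboxylic acid, would give a step beyond the scatter. Also open, on these data alone, is whether a longer chain in place of the methyl on the saturated chain carbon of compound 3 would separate that compound from compound 2.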